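Ethyl for cyclopropyl on the amine side chain

The source may hold more compounds than are shown below. What is called first, only, known or untested is meant among the compounds shown, and "the series" means these compounds.

Values in a functional assay on BT-483 cells (Homo sapiens) for cytotoxicity, read by MTT assay, with a stated time of 24 h; on this read-out higher numbers stand for weaker inhibition and lower numbers for stronger inhibition:
- compound 1 `CCNc1cc(-c2ccc(NC(=O)Nc3cccc(Cl)c3)cc2C(F)(F)F)ccn1`: 13300 nM
- compound 2 `O=C(Nc1cccc(Cl)c1)Nc1ccc(-c2ccnc(NCC3CC3)c2)c(C(F)(F)F)c1`: > 30000 nM (a limit, not a number)

Compound 2 stands at the limit of > 30000 nM in this assay, at which 1 of the 2 values shown sits. The next compound to be tested is compound 3 `CCCNc1cc(-c2ccc(NC(=O)Nc3cccc(Cl)c3)cc2C(F)(F)F)ccn1`. The change is ethyl in place of cyclopropyl on a saturated chain carbon bound to a nitrogen on an aromatic ring, or cyclopropylmethyl to propyl when cut one bond further out.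

For the measured compounds named here, only one measured step bears on this place: an at least 2.2-fold higher number from compound 1 to compound 2 (0.35 log units; beyond the scatter). On these data alone, that step puts cyclopropyl in where methyl stood, and its true size remains open since one end is a limit. Removing the cyclopropyl should therefore move the number down, though only modestly. The expected change is an at least 1.5-fold lower number from compound 2 to compound 3 (0.17 log units; that floor lies within the scatter), and it may not clear the usual scatter. For compound 3 the estimate in this assay is 20000 nM, with an expected range of 10000 nM to 40000 nM.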

Compound 3, half-maximal inhibitory concentration: 18500 nM
The estimate for compound 3 lay 1.1-fold (0.03 log units) above the measured number; low and high end bracket the measured number.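

In this assay, methyl in place of hydrogen on the saturated chain carbon gives a 1.4-fold higher number from compound 1 to compound 3 (0.14 log units; within the scatter), so the propylamino chain cannot be told apart from the shorter chain of compound 1. Ethyl in place of cyclopropyl gives an at least 1.6-fold lower number from compound 2 to compound 3 (0.20 log units; that floor lies within the scatter), which suggests that the ring, rather than the chain as such, goes with the higher number of compound 2, though the floor of that step does not clear the scatter. The true size of that step stays open: the limit of > 30000 nM in this assay, at which 1 of the 3 values shown sits.

On these data alone, whether a butyl chain, a branched isopropyl group or a terminal hydroxyl or amine on the chain would stay level with compound 3 remains open. So does whether a larger ring, such as cyclobutyl or cyclohexyl, would go with a higher number as cyclopropyl does.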